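The source may hold more compounds than are shown below. What is called first, only, known or untested is meant among the compounds shown, and "the series" means these compounds.

Compound 1 `Cc1ccccc1CNc1nn(-c2ccc(F)cc2F)cc1CNCCN1CCN(C)CC1` gives in an ADME assay on Huh-7 cells (Homo sapiens) for cytotoxicity (on this read-out lower numbers stand for higher toxicity in this test and higher numbers for lower toxicity in this test), a limit, > 20000 nM.
Compound 2 `Cc1ccc(-c2nn(-c3ccc(F)cc3F)cc2CNCCN2CCN(C)CC2)cc1` gives in this assay a limit, > 20000 nM.
Compound 3 `CN1CCN(CCNCc2cn(-c3ccc(F)cc3F)nc2-c2ccc(N(C)C)cc2)CC1` gives in this assay a limit, > 20000 nM.

Compound 3 thus stands at the limit of > 20000 nM in this assay, at which 3 of the 3 values shown sit, with nothing to set it apart from the other two. The steps a step that the two limits leave unreadable from compound 1 to compound 2, a step that the two limits leave unreadable from compound 1 to compound 3 and a step that the two limits leave unreadable from compound 2 to compound 3 are all unreadable, as each of their ends is a limit. Compound 4 `CN1CCN(CCNCc2cn(-c3ccc(F)cc3F)nc2-c2ccccc2Cl)CC1` differs from compound 3 by 2-chlorophenyl in place of 4-(dimethylamino)phenyl on an aromatic carbon. Within the data shown here, none of the measured steps can show how large a step to expect for this change; they show only three compounds resting at the same limit. Compound 4 is therefore expected to end at that limit as well, so that a number no higher from compound 3 to compound 4 (the limit leaves the size open) is expected to show no readable step. The estimate for compound 4 is 20000 nM, within 10000 nM to 40000 nM.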

Compound 4, half-maximal cytotoxic concentration: > 20000 nM
Compound 4 was reported as a limit (the forecaster's own chance of this, stated with the estimate: 85%); the middle value lies on the limit itself.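

Compound 4 also rests at a limit, so its steps from compound 1, compound 2 and compound 3 cannot be read: the limit of > 20000 nM in this assay, at which 4 of the 4 values shown sit. The compounds shown leave open whether these group changes alter the read-out in this assay at all.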